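The source may report more compounds than this note shows. Statements on the series, on what has been measured and on what is new or still open speak of the compounds shown alone.

In a functional assay on PC-3 cells (Homo sapiens) for inhibition, read by sulforhodamine B assay, with a stated time of 48 h (a higher number here means a weaker inhibitor of growth, a lower number a stronger inhibitor of growth), compound 3 (`CC(C)(C)NCc1c(C(=O)O)nn(-c2ccc(Cl)cc2)c1-c1ccc(Cl)cc1`) is known only as a limit, > 599000 nM. Compound 1 (`CCOC(=O)c1nn(-c2ccc(Cl)cc2)c(-c2ccc(Cl)cc2)c1CNC(C)(C)C`) gives 196000 nM; > 519000 nM (2 entries). Compound 2 (`CC(C)(C)NCc1c(C(=O)O)nn(-c2ccccc2)c1-c1ccc(Cl)cc1`) gives 145000 nM. Compound 4 (`CC(C)(C)NCc1c(C(=O)O)nn(-c2ccc(Cl)cc2)c1-c1ccc([N+](=O)[O-])cc1`) carries nitro in place of chloro on an aromatic carbon, 4-chlorophenyl to 4-nitrophenyl: nitro in place of chloro on an aromatic carbon. Among the measured compounds shown here, no measured step makes this exchange. The nearest is an at least 4.1-fold higher number from compound 2 to compound 3 (0.61 log units; beyond the scatter), chloro in place of hydrogen on an aromatic carbon, beyond the scatter and resting on a limit. It suggests that removing that chloro may lower the number in this assay, so a modest move in that direction is expected, loosely sized: an at least 2.3-fold lower number from compound 3 to compound 4 (0.37 log units; beyond the scatter). For compound 4 the estimate is 250000 nM, with an expected range of 80000 nM to 700000 nM.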

Compound 4, concentration for 50% growth inhibition: > 583000 nM
Compound 4: no number, only a limit; the forecaster's own chance of this, stated with the estimate: 40%; at least 2.3-fold (0.36 log units) between middle value and limit.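

Compound 3 and compound 4 are both known only as limits in this assay, and the step between them cannot be read. Going by these compounds, it remains open whether nitro in place of chloro on an aromatic carbon changes growth inhibition at all, and in which direction.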